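This account rests on a few compounds, and the source may have more. Where it says the series, first, only, none or still open, it means among the compounds named here.

In a functional assay on blood (Homo sapiens), with a stated time of 60 min, in the presence of a further agent that is not named here (a lower number here means that less compound is needed, a higher number that more compound is needed for the effect), compound 2 (`O=C(Nc1ccccc1O)C1(S(=O)(=O)c2ccc(Oc3ccc(OC(F)(F)F)cc3)cc2)CCC2(CCNCC2)C1`) gives > 15000 nM, which is a limit of the assay and not a number. Compound 1 (`O=S(=O)(c1ccc(Oc2ccc(OC(F)(F)F)cc2)cc1)C1CCC2(CCNCC2)C1`) gives > 15000 nM, also a limit. Together they form (the limit of > 15000 nM in this assay, at which 2 of the 2 values shown sit). Among the measured compounds shown here, the one measured step is a step that the two limits leave unreadable from compound 1 to compound 2, with (2-hydroxyphenyl)carbamoyl in place of hydrogen on a saturated ring carbon. Compound 3 (`CNC(=O)NC(=O)C1(S(=O)(=O)c2ccc(Oc3ccc(OC(F)(F)F)cc3)cc2)CCC2(CCNCC2)C1`) keeps the core of compound 2 and has methylcarbamoyl in place of 2-hydroxyphenyl on an amide-type nitrogen. The measured step has no readable size, so it offers no size or direction to carry over to this change in this assay. For the measured compounds named here, the only guide is compound 2, whose > 15000 nM is a limit. Compound 3 is therefore expected to stay close to that limit, and the expected change is a number no higher from compound 2 to compound 3 (the limit leaves the size open). For compound 3 the estimated value is 15000 nM, with an expected range from 5000 nM to 40000 nM.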

Compound 3, half-maximal effective concentration: < 400 nM
Compound 3: no number, only a limit; the forecaster's own chance of this, stated with the estimate: 80%; at least 37-fold (1.57 log units) between middle value and limit.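

At the amide-type nitrogen the side group now matters: in this assay, methylcarbamoyl in place of 2-hydroxyphenyl gives an at least 37-fold lower number from compound 2 to compound 3 (1.57 log units; beyond the scatter). The earlier step could not be read, so the saturated ring carbon had shown no effect of any substitution; with hydrogen replaced by (methylcarbamoyl)carbamoyl, there is now an at least 37-fold lower number from compound 1 to compound 3 (1.57 log units; beyond the scatter), which shows that a group at this carbon can go with a much lower number, though (2-hydroxyphenyl)carbamoyl did not. The value of compound 3 is itself a limit and not a number: the limit of < 400 nM in this assay, at which 1 of the 3 values shown sits.

How far below that limit compound 3 lies remains open, as does which part of methylcarbamoyl accounts for the step. Whether an acetyl group or a plain methyl group on the same nitrogen would behave alike cannot be told from these compounds.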